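The compounds below may be only part of what the source reports. "The series", "measured", "known", "first", "only" and "open" are said of these compounds alone.

Among the compounds with values here, in a functional assay on A-431 cells (Homo sapiens) for cytotoxicity (a higher number here means that more compound is needed for the effect, a lower number that less compound is needed), three compounds built on one core have numbers so far: compound 1 (`COC1=C(C)C(=O)/C(=C(O)/C=C/c2ccc(F)cc2)C(=O)C1(C)C`) gives 4.1 ug/mL, compound 2 (`CCc1ccc(/C=C/C(O)=C2/C(=O)C(C)=C(OC)C(C)(C)C2=O)cc1`) gives 12 ug/mL, and compound 3 (`COC1=C(C)C(=O)/C(=C(O)/C=C/c2cc(C)cc(C)c2)C(=O)C1(C)C`) gives 4 ug/mL. Compound 3 thus stands level with compound 1 within the scatter, and both sit apart from compound 2. Compound 4 (`COC1=C(C)C(=O)/C(=C(O)/C=C/c2nccs2)C(=O)C1(C)C`) keeps the core of compound 3 and alters a single group: 1,3-thiazol-2-yl in place of 3,5-dimethylphenyl on a double-bonded chain carbon bound to a double-bonded chain carbon.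

Within the data shown here, two measured steps touch this same place. One is a 1.0-fold lower number from compound 1 to compound 3 (0.01 log units; within the scatter), which is no real change, and the other is a 3.0-fold lower number from compound 2 to compound 3 (0.48 log units; beyond the scatter), which is modest. The related step of a 2.9-fold higher number from compound 1 to compound 2 (0.47 log units; beyond the scatter) is of similar size. Among the measured compounds shown here, none of these steps brings in 1,3-thiazol-2-yl, so the data offer no direct precedent for this group. Since the largest step at this place is only the modest 3.0-fold lower number from compound 2 to compound 3 (0.48 log units; beyond the scatter), no large move is expected in this assay. Compound 3, at 4 ug/mL, shares the low end of the numbers seen so far, so any move is expected to lean towards a higher number, probably without clearly leaving the scatter. The expected step is a 1.5-fold higher number from compound 3 to compound 4 (0.18 log units; within the scatter). For compound 4 the estimated value is 6 ug/mL, with an expected range of 2 ug/mL to 18 ug/mL.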

Compound 4, concentration for half-maximal effect: 6 ug/mL
Compound 4: the middle estimate sits on the measured number at the digits printed, and the stated range covers the measured number.
By their numbers in this assay, from the lowest: compounds 3, 1, 4 and 2 (each within the scatter of the next, the first and the last beyond it).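

In this assay, within the data shown here, 1,3-thiazol-2-yl is the first group at this place that is not a six-membered aromatic ring of carbon only, and every step to it stays within the scatter (a 1.5-fold higher number from compound 3 to compound 4 (0.18 log units; within the scatter); a 1.5-fold higher number from compound 1 to compound 4 (0.17 log units; within the scatter); a 2.0-fold lower number from compound 2 to compound 4 (0.30 log units; within the scatter)). Among these compounds, the place on a double-bonded chain carbon bound to a double-bonded chain carbon therefore takes a five-membered aromatic ring with 2 hetero atoms and 2 hydrogen-bond acceptors without a step beyond the scatter, whereas the only steps beyond it so far lie among the carbon-only aromatic groups, between compound 2 and each of compound 1 and compound 3; compound 4 falls clearly on neither side of that gap. Nothing measured here accounts for this tolerance of the change of ring.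

The compounds shown leave open whether a group without an aromatic ring at this place, such as a cyclohexyl ring or a longer alkyl chain, would stay within the same narrow band, and whether a charged group, such as a carboxylic acid or a primary amine on the ring, would do so. They also leave open whether the ring nitrogen or the ring sulfur matters, which thiophen-2-yl and pyridin-2-yl could help to separate.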